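Adding a Fluoro to the Weaker Compound 2

The source may report more compounds than this note shows. Statements on the series, on what has been measured and on what is new or still open speak of the compounds shown alone.

Measured in a functional assay on the whole organism with Scenedesmus acutus as the target, with a stated time of 20 h; a lower number here means a stronger inhibitor, a higher number a weaker inhibitor:
Compound 1 `CCOC(=O)c1cc(N2C(=O)C3=C(CCCC3)C2=O)c(F)cc1Cl` gives 87.1 nM
Compound 2 `CCC(C)OC(=O)c1cc(N2C(=O)C3=C(CCCC3)C2=O)ccc1Cl` gives 9770 nM

Compound 2 has the higher number of the two, so it is the weaker inhibitor, and the gap to compound 1 lies well beyond the usual scatter. Compound 3 `CCC(C)OC(=O)c1cc(N2C(=O)C3=C(CCCC3)C2=O)c(F)cc1Cl` is compound 2 with fluoro in place of hydrogen on an aromatic carbon. No single change of this kind has been measured. Within the data shown here, the only guide is compound 1, which has this fluoro and a different ester and gives 87.1 nM in this assay. The expected step of a 49-fold lower number from compound 2 to compound 3 (1.69 log units; beyond the scatter) is therefore a large fall in the number, beyond the scatter. Compound 3 is estimated at 200 nM with an expected range from 50 nM to 1500 nM as its likely spread.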

Compound 3, half-maximal inhibitory concentration: 74.1 nM
For compound 3 the middle estimate is 2.7-fold (0.43 log units) above the measured one; measured number inside the range.
By their numbers in this assay, from the lowest: compounds 3 and 1 (each within the scatter of the next); then compound 2.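

In this assay, fluoro in place of hydrogen on this aromatic carbon, ortho to a large group, is now seen alone as a single change, and it gives a 130-fold lower number from compound 2 to compound 3 (2.12 log units; beyond the scatter). With the fluoro present, the change in the ester chain matters far less, since ethyl in place of hydrogen gives a 1.2-fold lower number from compound 1 to compound 3 (0.07 log units; within the scatter). Nothing measured here explains why this one atom has so large an effect.

Going by these compounds, whether chloro, methoxy or trifluoromethyl could stand in for fluoro at this position remains open. So does the size of the fluoro step with other esters, such as one with a longer chain.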